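The compounds below may be only part of what the source reports. "The series", "measured", "known", "first", "only" and "open" are said of these compounds alone.

Measured so far in an ADME assay on RD cells (Homo sapiens) for cytotoxicity; on this read-out lower numbers stand for higher toxicity in this test and higher numbers for lower toxicity in this test:

Compound 1 `O=C1/C(=N\NC(=S)Nc2ccccc2)c2ccccc2N1c1ccccc1`: compound 1 gives > 25000 nM, a limit of the assay.
Compound 2 `O=C1Nc2ccccc2/C1=N/NC(=S)Nc1ccc(-n2cccn2)cc1`: compound 2 gives > 25000 nM, a limit of the assay.
Compound 3 `O=C1Nc2ccccc2/C1=N/NC(=S)Nc1ccccc1`: compound 3 gives > 25000 nM, a limit of the assay.

Compound 3 thus stands at the limit of > 25000 nM in this assay, at which 3 of the 3 values shown sit; no number is known for it, only a limit, and the same holds for the two compounds around it. The steps into compound 3, a step that the two limits leave unreadable from compound 1 to compound 3 and a step that the two limits leave unreadable from compound 2 to compound 3, are therefore of unreadable size.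

Compound 4 `O=C1Nc2ccccc2/C1=N/NC(=S)Nc1ccc(Cl)cc1` differs from compound 3 by chloro in place of hydrogen on an aromatic carbon. Within the data shown here, no measured step touches this change. With all three values in this assay sitting at the limit, no step beyond the scatter is expected from compound 3 to compound 4 in this assay, that is a step that the limit leaves unreadable from compound 3 to compound 4. Compound 4 is expected to give about 40000 nM in this assay, within 15000 nM to 100000 nM, most likely again as a limit.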

Compound 4, half-maximal cytotoxic concentration: > 25000 nM
Compound 4 was reported as a limit (the forecaster's own chance of this, stated with the estimate: 75%); the middle value lies beyond the limit too.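

No new step can be read from compound 2 or compound 3 to compound 4 in this assay, since all the compounds share one limit: the limit of > 25000 nM in this assay, at which 4 of the 4 values shown sit.

The compounds shown leave open whether any true value differs among them.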